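A few compounds are considered here, and "the series" means these few. Any claim that something is new, unique, unknown or untested is made for them only; others in the source may bear on it.

Going by the values given here, in an ADME assay on Vero cells (Chlorocebus sabaeus) for cytotoxicity, read by MTT assay, with a stated time of 72 h (a higher number here means that more compound is tolerated, a lower number that less compound is tolerated), compound 2 (`COc1c(N2CCN(C/C(C)=N/Nc3ccccc3)C(C)C2)c(F)cc2c(=O)c(C(=O)O)cn(C3CC3)c12`) gives 11.1 ug/mL, the lower of the two numbers so far, against compound 1 (`COc1c(N2CCN(CC(C)=O)C(C)C2)c(F)cc2c(=O)c(C(=O)O)cn(C3CC3)c12`) at 500 ug/mL. The next compound to be read is compound 3 (`COc1c(N2CCN(CC/C(C)=N/O)C(C)C2)c(F)cc2c(=O)c(C(=O)O)cn(C3CC3)c12`), and the change from compound 2 is a group of 5 heavy atoms (3 carbon, 1 nitrogen, 1 oxygen; no ring) in place of a group of 10 heavy atoms (8 carbon, 2 nitrogen; one six-membered aromatic ring of carbon only), on a saturated chain carbon bound to an amine nitrogen in a ring. Among the compounds with values here, the one measured step that bears on this is a 45-fold lower number from compound 1 to compound 2 (1.65 log units; beyond the scatter). That large step, beyond the scatter, came with the group holding the six-membered aromatic ring of carbon only entering at the same place. Within the data shown here, the new change removes that ring, so it runs the opposite way, but only in part: the entering group is not the group of compound 1, and no measured compound carries it. With a single step to go on, a sizeable rise is expected, and a full return to the number of compound 1 is not assumed. The expected change is a 14-fold higher number from compound 2 to compound 3 (1.13 log units; beyond the scatter). For compound 3 the estimated value is 150 ug/mL, with an expected range of 40 ug/mL to 500 ug/mL.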

Compound 3, half-maximal cytotoxic concentration: 44.2 ug/mL
For compound 3 the middle estimate is 3.4-fold (0.53 log units) above the measured one, within the range that was stated.
By their numbers in this assay, from the lowest: compound 2; then compound 3; then compound 1.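

Working notes on the side chain, read in this assay: the group of 5 heavy atoms, with no ring, in place of the group holding the six-membered aromatic ring of carbon only gives a 4.0-fold higher number from compound 2 to compound 3 (0.60 log units; beyond the scatter) and so shows, for the first time, a rise beyond the scatter on removing that ring at this saturated chain carbon bound to an amine nitrogen in a ring. The ring cannot account for the whole fall seen in this series, since the data also show an 11-fold lower number from compound 1 to compound 3 (1.05 log units; beyond the scatter) with no ring in the entering group, and the low numbers at this place therefore do not depend on an aromatic ring being present. Nothing measured on hand offers an explanation for either step.

A ketone carried on the same chain as in compound 3 would be needed to separate the effect of chain length from that of the end group, as the two differ together between compound 1 and compound 3. Also open, from the compounds shown here alone, is where a primary amine, an alcohol or a carboxylic acid at this place would fall relative to compound 1 and compound 3.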